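The source may hold more compounds than are shown below. What is called first, only, known or untested is meant among the compounds shown, and "the series" means these compounds.

In an ADME assay on MT4 cells (Homo sapiens) for cytotoxicity (on this read-out lower numbers stand for higher toxicity in this test and higher numbers for lower toxicity in this test), compound 2 (`Cc1ccc(NC(=O)CSc2snnc2-c2ccc(F)cc2F)c(Br)c1`) gives > 273000 nM, which is a limit and not a number. Compound 1 (`Cc1ccc(NC(=O)CSc2snnc2-c2ccccc2)c(Br)c1`) gives > 297000 nM, also a limit, so no exact value stands beside compound 2. Compound 3 (`O=C(CSc1snnc1-c1ccc(F)cc1F)Nc1ccccc1Br`) differs by hydrogen in place of methyl on an aromatic carbon, 2-bromo-4-methylphenyl to 2-bromophenyl. Among the compounds with values here, the only measured step, a step that the two limits leave unreadable from compound 1 to compound 2, lies elsewhere in the structure and gives no size to carry over. No shift beyond the scatter is expected in this assay, and the expected step is a step that the limit leaves unreadable from compound 2 to compound 3. The estimate for compound 3 is 280000 nM, with an expected range of 100000 nM to 300000 nM.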

Compound 3, half-maximal cytotoxic concentration: 144000 nM
For compound 3 the middle estimate is 1.9-fold (0.29 log units) above the measured one; measured number inside the range.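

In this assay, within the data shown here, compound 3 gives 144000 nM, the only exact value among the three compounds. Hydrogen in place of methyl on this aromatic carbon, meta to a bromo group and para to a large group, gives an at least 1.8-fold lower number from compound 2 to compound 3 (0.27 log units; that floor lies within the scatter), and this floor alone establishes no shift beyond the scatter. The step is only a floor because compound 2 carries a limit: the limit of > 273000 nM in this assay, at which 1 of the 3 values shown sits.

The step between compound 1 and compound 2 cannot be read, leaving the 2,4-difluorophenyl change without a size. As far as these compounds go, whether an amine or a carboxylic acid at this position would give a different number remains open.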